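This account rests on a few compounds, and the source may have more. Where it says the series, first, only, none or still open, it means among the compounds named here.

Measured so far:
compound 1, `Cc1ccc(Nc2cc(NC(=O)Nc3c(Cl)cccc3Cl)ncn2)cc1F` — in a functional assay on NCI-H520 cells (Homo sapiens) for inhibition, read by MTT assay, with a stated time of 48 h, tested at 10 uM (a lower number here means less inhibition, a higher number more inhibition at the concentration tested (going by the name of the read-out)), compound 1 gives 33.5%
compound 2, `COc1ccc(C(F)(F)F)cc1Nc1cc(NC(=O)Nc2c(Cl)cccc2Cl)ncn1` — compound 2 gives 33%
compound 3, `COc1cc(NC(=O)Nc2cc(Nc3cc(C)cc(F)c3)ncn2)cc(OC)c1` — compound 3 gives 24.5%

The three numbers sit close together. Compound 3 has the lowest of the three, but its gap to compound 2 and its gap to compound 1 both fall within the usual scatter of repeated measurements, so no order among the three compounds can be read from these values, and none of them can be said to have a higher or lower inhibition in this assay than the others. All three share the same core; compound 3 differs from compound 1 and compound 2 in both of the groups hanging off it, so no single change between measured compounds is available for comparison.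

Compound 4, `COc1cc(NC(=O)Nc2cc(Nc3ccc(C)c(C)c3)ncn2)cc(OC)c1`, differs from compound 3 in one place:

3,4-dimethylphenyl in place of 3-fluoro-5-methylphenyl on a nitrogen on an aromatic ring

Among the compounds with values here, no measured pair in the set isolates this change, so nothing here says in which direction it should move the number. The step expected in this assay is a number 0.5 percentage points higher from compound 3 to compound 4 (within the scatter), which is nothing beyond the scatter, and it has no clear direction. For compound 4 the expected value in this assay is 25%, with a range from 10% to 40%.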

Compound 4, a percentage reported as inhibition, at one concentration (the size of the read-out at that concentration, not a potency): 29.5%
Compound 4: middle estimate off by 4.5 percentage points, on the low side, and the stated range covers the measured number.
By their numbers in this assay, from the lowest: compounds 3, 4, 2 and 1 (each within the scatter of the next).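

In this assay, within the data shown here, 3,4-dimethylphenyl in place of 3-fluoro-5-methylphenyl on a nitrogen on an aromatic ring gives a number 5 percentage points higher from compound 3 to compound 4 (within the scatter), the first comparison that isolates a change in one place. For this pair, therefore, exchanging a group that carries fluorine for one of carbon only leaves the reading inside the scatter, and no direction can be assigned to the change. No measurement available here bears on the reason for this result.

As far as these compounds go, the two groups compared are closely matched, each a six-membered aromatic ring of carbon only with no hydrogen-bond donors or acceptors, so it remains open whether an amine or a carboxylic acid on this phenyl ring, or a morpholine in its place, would give a step beyond the scatter. The other group on the shared core also remains unresolved, since compound 1 and compound 2 each differ from compound 3 and compound 4 in more than one place and so offer no single-change comparison for it.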